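A few compounds are considered here, and "the series" means these few. Any claim that something is new, unique, unknown or untested is made for them only; others in the source may bear on it.

Measured in a functional assay on HL-60 cells (Homo sapiens) for inhibition, read by MTT assay, with a stated time of 48 h, tested at 10 uM; on this read-out higher numbers stand for more inhibition of growth at the one concentration tested and lower numbers for less inhibition of growth:

- Compound 1 `Cc1cc(=O)c2c(O)c(CN(C(C)C)C(C)C)c(O)c([C@H]3CCN(C)C[C@H]3O)c2o1`: 21%
- Compound 2 `Cc1oc2c([C@H]3CCN(C)C[C@H]3O)c(O)cc(O)c2c(=O)c1C(O)c1ccc(F)c(Br)c1`: 25%

In this assay, among the measured compounds shown here, compound 2 stands at 25%, and its only neighbour on the scale is compound 1 at 21%. The two numbers lie within the scatter of each other, so neither compound can be placed ahead of the other.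

Compound 3 `COc1ccc(C(O)c2c(C)oc3c([C@H]4CCN(C)C[C@H]4O)c(O)cc(O)c3c2=O)cc1Br` is the next compound to be tested. It differs from compound 2 in one place: methoxy in place of fluoro on an aromatic carbon. Methoxy stands in place of fluoro on an aromatic carbon, ortho to a bromo group and para to a large group, which turns 3-bromo-4-fluorophenyl into 3-bromo-4-methoxyphenyl.

For the measured compounds named here, no measured pair of compounds differs in only one place, so the data do not size this change directly. No step beyond the scatter is expected, and neither direction is favoured. The expectation therefore starts from compound 2 at 25%. The expected change is a number 1 percentage points lower from compound 2 to compound 3 (within the scatter), which would stay within the scatter. For compound 3 the estimated value is 24%, with an expected range from 8% to 42%.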

Compound 3, percent growth inhibition at one concentration: 23%
The estimate for compound 3 lay 1 percentage points above the measured number; measured number inside the range.
By their numbers in this assay, from the lowest: compounds 1, 3 and 2 (each within the scatter of the next).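

In this assay, among the compounds shown here, the exchange of fluoro for methoxy on the aromatic carbon ortho to the bromo group and para to a large group reads as a number 2 percentage points lower from compound 2 to compound 3 (within the scatter) and is the first step between two compounds that differ in one place. It shows that, at this position, the 3-bromo-4-methoxyphenyl group of compound 3 and the 3-bromo-4-fluorophenyl group of compound 2 cannot be told apart on this read-out, even though methoxy brings two heavy atoms and one hydrogen-bond acceptor where fluoro had one heavy atom and none. Nothing at hand explains this result.

The compounds shown leave open whether any group on this aromatic carbon would give a step beyond the scatter, for example an amine, a carboxylic acid or a longer alkoxy chain. They also leave open what the bromo group contributes, since both compounds carry it, and a single step at one concentration says nothing about how either compound would read at other concentrations.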